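Carboxy to ethoxycarbonyl: notes on compound 3

The source may report more compounds than this note shows. Statements on the series, on what has been measured and on what is new or still open speak of the compounds shown alone.

Measured so far in a physicochemical assay for metabolic stability, read by LC-MS, in phosphate buffer, with a stated time of 120 min, at pH 7.4, tested at 1 uM (a higher number here means that more of the compound is left, a lower number that less of the compound is left), for two compounds:
Compound 1 `CC#CCn1c(N2CCC[C@@H](N)C2)nc2c1c(=O)n(Cc1ccc(Br)cc1C(=O)OC)c(=O)n2C` gives 99.4%
Compound 2 `CC#CCn1c(N2CCC[C@@H](N)C2)nc2c1c(=O)n(Cc1ccc(Cl)cc1C(=O)O)c(=O)n2C` gives 101%

Compound 2 stands level with compound 1 within the scatter, and both numbers lie close together at the top of the read-out. The next compound is compound 3 `CC#CCn1c(N2CCC[C@@H](N)C2)nc2c1c(=O)n(Cc1ccc(Cl)cc1C(=O)OCC)c(=O)n2C` and its change from compound 2 is ethyl in place of hydrogen on an oxygen next to a carbonyl group which, cut one bond further out, reads carboxy to ethoxycarbonyl. Going by the values given here, only one measured step bears on this, namely a number 1.6 percentage points higher from compound 1 to compound 2 (within the scatter) and it is a small one. Compound 1 carries methoxycarbonyl where compound 3 carries ethoxycarbonyl, so the measured step runs from an ester to the acid, though it also exchanges bromo for chloro. No ethyl ester has been measured yet. A step beyond the scatter in this assay is not expected, and any drift would more likely be downward than upward. The expected size is a number 3 percentage points lower from compound 2 to compound 3 (within the scatter) and this stays inside the scatter. For compound 3 the estimate is 98% with an expected range from 90% to 104% in a single measurement.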

Compound 3, percent of the compound remaining: 99.5%
Estimate against measurement, compound 3: 1.5 percentage points below; low and high end bracket the measured number.
By their numbers in this assay, from the lowest: compounds 1, 3 and 2 (each within the scatter of the next).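

In this assay, going by these compounds alone, the ethyl on an oxygen next to a carbonyl group gives a number 1.5 percentage points lower from compound 2 to compound 3 (within the scatter) and so sets the free acid and its ethyl ester level, the first step that touches this group alone, since the earlier step from ester to acid also exchanged bromo for chloro. Across the aryl groups, 4-chloro-2-(ethoxycarbonyl)phenyl in place of 4-bromo-2-(methoxycarbonyl)phenyl gives a number 0.1 percentage points higher from compound 1 to compound 3 (within the scatter) and thus the two esters and the acid all stand together near the top of the read-out, with no step among them beyond the scatter. No measured information at hand accounts for these level readings.

On these data alone, whether a longer chain on that oxygen, such as butyl, or an amide in place of the ester would also stand level stays open. The step between the two esters also joins two exchanges, bromo to chloro and methyl to ethyl, and a methoxycarbonyl paired with chloro would be needed to tell them apart.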